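Swapping a fluorinated sulfur group for pentafluoroethyl

The compounds below may be only part of what the source reports. "The series", "measured", "known", "first", "only" and "open" are said of these compounds alone.

Measured compounds:
compound 1 `CC(O)(COc1cc(C(F)(F)F)cc(C(F)(F)F)c1)C(=O)Nc1cccc(S(F)(F)(F)(F)F)c1` gives 2800 nM
compound 2 `CC(O)(COc1cccc(S(F)(F)(F)(F)F)c1)C(=O)Nc1cc(C(F)(F)F)cc(C(F)(F)F)c1` gives 2700 nM
compound 3 `CC(O)(COc1cccc(C(F)(F)C(F)(F)F)c1)C(=O)Nc1cc(C(F)(F)F)cc(C(F)(F)F)c1` gives 9500 nM

All values come from a functional assay on VCaP cells (Homo sapiens) for antiproliferative activity, read by propidium iodide staining, with a stated time of 96 h; a higher number here means a weaker inhibitor, a lower number a stronger inhibitor. Compound 1 and compound 2 have the same atoms joined differently; the difference between the two cores is not broken down here, and their two values lie within the scatter of each other. Compound 3 differs from compound 2 in one place, (a group of 7 heavy atoms (2 carbon, 5 fluorine; no ring) in place of a group of 6 heavy atoms (5 fluorine, 1 sulfur; no ring), on an aromatic carbon), and that change costs a 3.5-fold higher number from compound 2 to compound 3 (0.55 log units; beyond the scatter).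

Compound 4 `CC(O)(COc1cc(C(F)(F)F)cc(C(F)(F)F)c1)C(=O)Nc1cccc(C(F)(F)C(F)(F)F)c1` is not yet measured. It differs from compound 1 by a group of 7 heavy atoms (2 carbon, 5 fluorine; no ring) in place of a group of 6 heavy atoms (5 fluorine, 1 sulfur; no ring), on an aromatic carbon, the same kind of change as between compound 2 and compound 3; the place lines match word for word, although the two cores themselves differ in the arrangement of their atoms. Among the compounds with values here, the one precedent for this change is the weakening seen from compound 2 to compound 3, and nothing among the three measured compounds contradicts it, though a single example is a thin basis.

For compound 4 a weakening of about the same size as the earlier one is expected, a 3.4-fold higher number from compound 1 to compound 4 (0.53 log units; beyond the scatter), because compound 1 starts from 2800 nM and the precedent is a 3.5-fold higher number from compound 2 to compound 3 (0.55 log units; beyond the scatter). Compound 4 is therefore estimated at 9500 nM in this assay, with a plausible range from 4000 nM to 25000 nM.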

Compound 4, half-maximal inhibitory concentration: 8000 nM
Beside the measured number, compound 4's estimate is 1.2-fold (0.07 log units) above it; measured number inside the range.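

In this assay, replacing the sulfur-bearing group of five fluorines with 1,1,2,2,2-pentafluoroethyl gives a 2.9-fold higher number from compound 1 to compound 4 (0.46 log units; beyond the scatter), so the weakening first seen on the core of compound 2 also appears on the core of compound 1. The two steps also agree in size: the same change on two cores in this assay, a 3.5-fold higher number (0.55 log units; beyond the scatter) from compound 2 to compound 3 and a 2.9-fold higher number (0.46 log units; beyond the scatter) from compound 1 to compound 4, 1.2-fold (0.09 log units) apart, within the scatter of two such steps Within this assay, the change therefore carries across these two closely related cores, whose atoms are the same but joined differently; this does not show that it would carry to a more distant core or to another assay, and two examples give no explanation for the weakening.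

The compounds shown leave open how other groups on this aromatic carbon would compare with the two tested here, for example a nitrile, a trifluoromethoxy group or a longer perfluoroalkyl chain. Also open, from the compounds shown here alone, is whether the step would keep its size if the hydroxyl group on the shared core gave way to an amine, or if one of the trifluoromethyl groups gave way to a chlorine atom.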